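Methoxy in place of fluoro: expected value for compound 4

The source may hold more compounds than are shown below. What is called first, only, known or untested is meant among the compounds shown, and "the series" means these compounds.

Measured so far in a functional assay on MGC-803 cells (Homo sapiens) for antiproliferative activity, read by CCK-8 assay, with a stated time of 72 h; on this read-out higher numbers stand for weaker inhibition and lower numbers for stronger inhibition:
compound 1 `O=C(Nc1ccc(-c2cnc3cc(Br)ccn23)cc1)c1ccc([N+](=O)[O-])o1`: 750 nM
compound 2 `COc1ccn2c(-c3ccc(NC(=O)c4ccc([N+](=O)[O-])o4)nc3)cnc2c1`: > 20000 nM
compound 3 `COc1ccn2c(-c3ccc(NC(=O)c4ccc([N+](=O)[O-])o4)cc3F)cnc2c1`: 1080 nM

In this assay compound 1 gives 750 nM and compound 3 gives 1080 nM; the two numbers sit within the usual scatter of each other, so no order between them is claimed. For compound 2 the assay reports only a limit, > 20000 nM, and no number (the limit of > 20000 nM in this assay, at which 1 of the 3 values shown sits). Compound 3 thus holds the higher of the two numbers shown, with compound 1 as its nearest neighbour, and the third value is a limit. Among the compounds with values here, no pair of measured compounds differs in a single place, so no measured step is available as a guide.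

Compound 4 `COc1ccn2c(-c3ccc(NC(=O)c4ccc([N+](=O)[O-])o4)cc3OC)cnc2c1` is not yet measured in this assay. It differs from compound 3 by methoxy in place of fluoro on an aromatic carbon. The methoxy group enters at a position ortho to a large group and meta to a large group, where the fluoro of compound 3 gave a number close to that of the unsubstituted compound 1. Within the data shown here, with no measured precedent for a methoxy at this place, a small step toward weaker inhibition is expected, of a size that may or may not exceed the scatter. Compound 4 is therefore estimated at 1600 nM, with a range from 500 nM to 6000 nM. The expected step is a 1.5-fold higher number from compound 3 to compound 4 (0.17 log units; within the scatter).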

Compound 4, half-maximal inhibitory concentration: > 20000 nM
Compound 4: only a limit was reported (the forecaster's own chance of this, stated with the estimate: 10%); at least 12-fold (1.09 log units) between middle value and limit.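

In this assay, methoxy in place of fluoro on this aromatic carbon, ortho to a large group and meta to a large group, gives an at least 18-fold higher number from compound 3 to compound 4 (1.26 log units; beyond the scatter). Compound 4 gives > 20000 nM, which is a limit of the assay and not a number, so the step has a floor but no measured end. No earlier pair differed in a single place, and this step is the first sign that the series is sensitive to what sits on this carbon, with a small exchange of substituent enough to reach the limit, now shared by a second compound: the limit of > 20000 nM in this assay, at which 2 of the 4 values shown sit.

The compounds shown carry only fluoro and methoxy at this place on the shared core, so it remains open whether chloro, methyl, hydroxy or an amine would stay close to compound 3 or also reach the limit. It is also open whether the step belongs to this carbon alone or whether methoxy on another carbon of the same ring would give a similar result, and the single step shown cannot say what lies behind it.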